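This account rests on a few compounds, and the source may have more. Where it says the series, first, only, none or still open, it means among the compounds named here.

Measured in an ADME assay on HCT-116 cells (Homo sapiens) for cytotoxicity, read by CellTiter-Glo, with a stated time of 72 h; a higher number here means a weaker inhibitor, a lower number a stronger inhibitor:
Compound 1 `Cc1cc(Cl)cc(Cl)c1S(=O)(=O)N1CCC(N2CCC(C)CC2)CC1`: > 5000 nM
Compound 2 `Cc1cc(C)c(S(=O)(=O)N2CCC(N3CCC(C)CC3)CC2)c(C)c1`: > 5000 nM
Compound 3 `CC1CCN(C2CCN(S(=O)(=O)c3cccnc3Cl)CC2)CC1`: > 10000 nM

None of these three entries is a number, and each is a limit of the assay. Compound 3 gives > 10000 nM in this assay, which is a limit. It stands at the limit of > 10000 nM in this assay, at which 1 of the 3 values shown sits, while the other two compounds stand at the limit of > 5000 nM in this assay, at which 2 of the 3 values shown sit. Within the data shown here, the series therefore offers no measured step from which to read a size.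

Compound 4 `Cc1ccc(S(=O)(=O)N2CCC(N3CCC(C)CC3)CC2)cc1C` differs from compound 3 at one place, with 3,4-dimethylphenyl in place of 2-chloropyridin-3-yl on a sulfonyl sulfur.

Compound 2 gives > 5000 nM, also a limit, and compound 1 gives > 5000 nM, a limit as well. Among the measured compounds shown here, with these two limits as the only guide, no step beyond the scatter is expected in either direction, and compound 4 may well be reported only as a limit too. The expected change is an at least 1.2-fold lower number from compound 3 to compound 4 (0.09 log units; that floor lies within the scatter), and this is a rough estimate measured against a limit. For compound 4 the estimated value in this assay is 8000 nM, with an expected range from 3000 nM to 20000 nM.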

Compound 4, half-maximal inhibitory concentration: > 5000 nM
Compound 4 was reported as a limit (the forecaster's own chance of this, stated with the estimate: 75%); the middle value is on the limit's open side.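

Compound 3 and compound 4 are both reported only as limits in this assay, and the step between them cannot be read. The compounds shown leave open where any of them would give a measured number in this assay, and whether 3,4-dimethylphenyl in place of 2-chloropyridin-3-yl on a sulfonyl sulfur changes that number at all.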